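A Benzyl Group Removed: Expected Efficacy of Compound 3

A few compounds are considered here, and "the series" means these few. Any claim that something is new, unique, unknown or untested is made for them only; others in the source may bear on it.

Of the compounds shown here, two have so far been measured in an in vitro functional assay on 1321-N1 cells for agonist activity at Free fatty acid receptor 1 (Homo sapiens), read by fluorescence, spectrophotometry and calcium flux; on this read-out lower numbers stand for smaller maximal responses and higher numbers for larger maximal responses. Compound 1, `O=C(O)CCc1ccc(C#Cc2ccnc(Cl)c2Cc2ccccc2)cc1`, gives 101% in this assay. Compound 2, `O=C(O)C1CC1c1ccc(C#Cc2cc(Cl)nc(Cl)c2)cc1`, gives 96% in this assay. Compound 1 holds the higher of the two numbers, yet its nearest neighbour, compound 2, lies within the scatter of it, so the two compounds cannot be ordered on this read-out; both reach essentially the full response of the reference. Among the compounds with values here, because they differ in more than one place, no single step connects them.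

Compound 3, `O=C(O)CCc1ccc(C#Cc2ccnc(Cl)c2)cc1`, has not yet been measured. It differs from compound 1 in one place: hydrogen in place of benzyl on an aromatic carbon. Since both measured compounds, compound 1 with 101% and compound 2 with 96%, sit near the top of the scale, the step of a number 11 percentage points lower from compound 1 to compound 3 (beyond the scatter) is expected to be small, at most a modest loss that may stay within the scatter. For compound 3 an efficacy of 90% is estimated, with a range from 60% to 110%.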

Compound 3, largest response reached (reported as efficacy), in percent of the reference or control that the assay uses: 94%
The estimate for compound 3 lay 4 percentage points below the measured number, within the range that was stated.
By their numbers in this assay, from the lowest: compounds 3, 2 and 1 (each within the scatter of the next).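

In this assay, within the data shown here, the exchange of benzyl for hydrogen on this aromatic carbon comes to a number 7 percentage points lower from compound 1 to compound 3 (within the scatter) and thus gives the first single-place comparison. The benzyl group, with its 7 heavy atoms and its six-membered aromatic ring of carbon only, can therefore be present or absent at this place, ortho to a chloro group and two atoms from the ring nitrogen, without a difference in maximal response that this read-out can separate from scatter. Compound 3 also shows that a response close to that of the reference does not require a large group at this carbon, and no other measurement at hand accounts for how little the read-out differs across this step.

On these data alone, what remains open is whether this tolerance extends to other groups on the same carbon, such as an amine, a methoxy group or a longer chain, which might leave the maximal response intact or lower it beyond the scatter. The read-out reports only the largest response reached, so these compounds leave open whether removing the benzyl group changes the concentration needed to reach that response.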